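The compounds below may be only part of what the source reports. "The series", "measured", "known", "first", "only" and "open" are said of these compounds alone.

Three compounds have been measured in an assay on CHO cells for displacement of a labelled ligand from adenosine receptor A3 (Homo sapiens), read by scintillation counting, tested at 10 uM; on this read-out lower numbers stand for less inhibition and higher numbers for more inhibition at the one concentration tested (going by the name of the read-out):

compound 1, `COc1ccc(-c2sc(N)c(C(=O)c3ccc(Cl)cc3)c2C)cc1`: 1%
compound 2, `CC(C)(C)Cc1csc(N)c1C(=O)c1cccc(Cl)c1`: 8%
compound 3, `CC(C)(C)Cc1c(-c2ccncc2)sc(N)c1C(=O)c1ccc(Cl)cc1`: 6%

All three numbers lie close together. Compound 3 sits within the scatter of compound 2, the nearest of the other two, and also within the scatter of compound 1, the furthest; no ranking among the three can be read from these figures, and all of them show little displacement of the labelled ligand at the one concentration tested.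

Compound 4, `CC(C)(C)Cc1c(-c2ccc(Cl)c(Cl)c2)sc(N)c1C(=O)c1ccc(Cl)cc1`, has not yet been measured. It is derived from compound 3 by a single change: 3,4-dichlorophenyl in place of pyridin-4-yl on an aromatic carbon. The aryl group that enters sits on the same carbon of the five-membered ring, next to the ring sulfur and next to the ring atom that bears the neopentyl group.

Going by the values given here, no pair of measured compounds differing in one place is available, so the size of such a change cannot be read from the data. Given that compound 3 itself gives 6% and that its neighbours compound 1 and compound 2 are equally low, the expectation for the step of a number 2 percentage points higher from compound 3 to compound 4 (within the scatter) is one of no change beyond the scatter. Compound 4 is therefore expected to give about 8% in this assay, with a likely range from -5% to 25%.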

Compound 4, a percentage reported as inhibition, at one concentration (the size of the read-out at that concentration, not a potency): 1%
Compound 4: the middle estimate sits 7 percentage points above what was measured; the measured number falls inside the stated range.
By their numbers in this assay, from the lowest: compounds 1, 4, 3 and 2 (each within the scatter of the next).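

In this assay, going by these compounds alone, the exchange of pyridin-4-yl for 3,4-dichlorophenyl, on the aromatic carbon next to the ring sulfur and next to the ring atom that bears the neopentyl group, gives the only step that can be read between compounds differing in one place, a number 5 percentage points lower from compound 3 to compound 4 (within the scatter) and so stays within the scatter. At this position, then, a six-membered aromatic ring with a hetero atom and one hydrogen-bond acceptor, and a chlorine-bearing ring of carbon only with no hydrogen-bond acceptor, cannot be told apart by this read-out, and both compounds show little displacement of the labelled ligand at the one concentration tested. Nothing measured here bears on the reason for this result.

The compounds shown leave open whether any group on this carbon can raise the read-out beyond the scatter, for instance an amine or a carboxylic acid carried on a longer chain in place of the aryl ring. Within the data shown here, they also leave open what an exchange of the neopentyl group or of the amino group would do on the same core, since no step at either place can be read.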